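Methyl in Place of Bromo on Two Different Cores

This account rests on a few compounds, and the source may have more. Where it says the series, first, only, none or still open, it means among the compounds named here.

Measured so far:
Compound 1, `O=C1/C(=C/c2ccc(Br)cc2)CCc2ccccc21`, in a functional assay on P388 cells (Mus musculus) for inhibition; on this read-out lower numbers stand for stronger inhibition and higher numbers for weaker inhibition: 20400 nM
Compound 2, `Cc1ccc(/C=C2\CCc3ccccc3C2=O)cc1`, in this assay: 17700 nM
Compound 3, `O=C1CCCCC/C1=C\c1ccc(Br)cc1`, in this assay: 16800 nM

Compound 1 and compound 2 share a core and differ by methyl in place of bromo on an aromatic carbon; this change made a step of a 1.2-fold lower number from compound 1 to compound 2 (0.06 log units; within the scatter). Compound 3 has a different core, and the difference between the two cores is not broken down here. The three numbers all lie within the usual scatter of one another, so no order among them can be read.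

Compound 4, `Cc1ccc(/C=C2\CCCCCC2=O)cc1`, has not yet been measured. It differs from compound 3 by methyl in place of bromo on an aromatic carbon. The place is described slightly differently here, para to a group of 9 heavy atoms rather than para to a large group, so this is the same kind of change as that from compound 1 to compound 2, made on the other core. Because the earlier step was a 1.2-fold lower number from compound 1 to compound 2 (0.06 log units; within the scatter), the step from compound 3 to compound 4 in this assay is expected to be of similar size, a 1.2-fold lower number from compound 3 to compound 4 (0.06 log units; within the scatter), resting on that single earlier pair. Compound 4 is therefore estimated at 14500 nM, with a range of 7000 nM to 30000 nM.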

Compound 4, half-maximal inhibitory concentration: > 50000 nM
Compound 4 was reported as a limit; the forecaster's own chance of this, stated with the estimate: 5%; at least 3.4-fold (0.53 log units) between middle value and limit.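

In this assay, methyl in place of bromo did not carry over unchanged from one core to the other: the same change on two cores in this assay, a 1.2-fold lower number (0.06 log units; within the scatter) from compound 1 to compound 2 and an at least 2.9-fold higher number (0.47 log units; beyond the scatter) from compound 3 to compound 4, at least 3.4-fold (0.53 log units) apart, beyond the scatter of two such steps On the core of compound 3, the change gave an at least 2.9-fold higher number from compound 3 to compound 4 (0.47 log units; beyond the scatter), so the step seen on the core of compound 1 did not foretell the step on this second core. Compound 4 is reported only as a limit, > 50000 nM, which leaves the full size of its step unknown, and a single pair on each core does not show why the two steps differ or establish a rule for this change across the series: the limit of > 50000 nM in this assay, at which 1 of the 4 values shown sits.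

The compounds shown leave open whether the step on the core of compound 3 is tied to methyl, or whether chloro, methoxy or an amine on that aromatic carbon would give a similar result. They also leave open how methyl in place of bromo would behave on any further core.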